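The source may hold more compounds than are shown below. What is called first, only, known or untested is meant among the compounds shown, and "the series" means these compounds.

Compound 1 `COc1cc(-c2ccnc3cc(-c4ccc(F)cc4)nn23)cc(OC)c1OC`: in a functional assay on A549 cells (Homo sapiens) for inhibition, read by CCK-8 assay, with a stated time of 48 h (on this read-out higher numbers stand for weaker inhibition and lower numbers for stronger inhibition), compound 1 gives 3800 nM.
Compound 2 `COc1cc(-c2ccnc3cc(-c4c[nH]c5ccccc45)nn23)cc(OC)c1OC`: compound 2 gives 29 nM.
Compound 3 `COc1cc(-c2ccnc3cc(-c4cccc(C)c4)nn23)cc(OC)c1OC`: compound 3 gives 5730 nM.

Compound 2 has the lowest number of the three, with a 130-fold lower number from compound 1 to compound 2 (2.12 log units; beyond the scatter) and a 200-fold higher number from compound 2 to compound 3 (2.30 log units; beyond the scatter), while a 1.5-fold higher number from compound 1 to compound 3 (0.18 log units; within the scatter) shows the two plain phenyl variants close together. Compound 4 `COc1cc(-c2ccnc3cc(-c4ccc5ccn(C)c5c4)nn23)cc(OC)c1OC` changes the same position of compound 2: 1-methyl-1H-indol-6-yl in place of 1H-indol-3-yl on an aromatic carbon. The two large steps indicate that the group on this carbon matters greatly, and the 1H-indol-3-yl of compound 2 stands alone as the strong one. Because compound 2 reaches 29 nM only with that group, compound 4 is expected to give a higher number, a 17-fold higher number from compound 2 to compound 4 (1.24 log units; beyond the scatter), although a fused two-ring group is kept. The estimate for compound 4 is 500 nM, ranging from 80 nM to 3000 nM.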

Compound 4, half-maximal inhibitory concentration: 829 nM
Compound 4: middle estimate off by 1.7-fold (0.22 log units), on the low side; low and high end bracket the measured number.
By their numbers in this assay, from the lowest: compound 2; then compound 4; then compounds 1 and 3 (each within the scatter of the next).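

In this assay keeping a fused two-ring group does not by itself hold the low number, with a 29-fold higher number from compound 2 to compound 4 (1.46 log units; beyond the scatter) even though both rings remain. Yet 1-methyl-1H-indol-6-yl still stands apart from the plain phenyl variants, with a 6.9-fold lower number from compound 3 to compound 4 (0.84 log units; beyond the scatter) and a 4.6-fold lower number from compound 1 to compound 4 (0.66 log units; beyond the scatter) on this read-out, so this carbon now shows three levels rather than two. The methyl and the attachment point change together here, leaving open how 1H-indol-6-yl or 1-methyl-1H-indol-3-yl would read, or an amine on this carbon. Nothing available explains these differences.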